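The source may report more compounds than this note shows. Statements on the series, on what has been measured and on what is new or still open speak of the compounds shown alone.

Compound 1 `COc1cc(OC)c(/C=C/S(=O)(=O)Cc2ccc(OC)c(N)c2)c(OC)c1` is the reference point here. For the measured compounds named here, in a functional assay on DU-145 cells (Homo sapiens) for cytotoxicity, read by trypan blue exclusion, with a stated time of 96 h (on this read-out higher numbers stand for weaker inhibition and lower numbers for stronger inhibition), compound 1 gives 4 nM, the lower of the two numbers measured so far. Going by the values given here, the only other measured compound is compound 2 `COc1cc(OC)c(/C=C/S(=O)(=O)Cc2ccc(Cl)cc2N)c(OC)c1`, and compound 2 gives 2500 nM. The unmeasured compound 3 `COC(=O)C(F)(F)Nc1cc(CS(=O)(=O)/C=C/c2c(OC)cc(OC)cc2OC)ccc1OC` keeps the core of compound 1 and differs at one place: difluoro(methoxycarbonyl)methyl in place of hydrogen on a nitrogen on an aromatic ring. In words, difluoro(methoxycarbonyl)methyl stands in place of hydrogen on a nitrogen on an aromatic ring.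

Among the compounds with values here, only one measured step offers any guidance, and it is indirect: a 630-fold higher number from compound 1 to compound 2 (2.80 log units; beyond the scatter). That large loss shows that this assay can respond sharply to a change in the aromatic group of compound 1. However, neither measured compound carries anything but hydrogen on that nitrogen, so the data do not directly show what this change will do. With compound 1 at such a low number, a rise seems the likelier direction, though a modest one, and the uncertainty is wide. The expected step is a 7.5-fold higher number from compound 1 to compound 3 (0.88 log units; beyond the scatter), smaller than the one measured. For compound 3 the estimated value is 30 nM, with an expected range from 5 nM to 300 nM.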

Compound 3, half-maximal inhibitory concentration: 250 nM
Compound 3: the middle estimate sits 8.3-fold (0.92 log units) below what was measured; measured number inside the range.
By their numbers in this assay, from the lowest: compound 1; then compound 3; then compound 2.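

For the compounds shown here, compound 3 is the first case here in which the nitrogen itself is changed, and placing difluoro(methoxycarbonyl)methyl in place of hydrogen on this nitrogen gives a 63-fold higher number from compound 1 to compound 3 (1.80 log units; beyond the scatter) in this assay. This shows that the read-out responds strongly to a change at this one place, even with the rest of compound 1 left intact, and that the amino form with its hydrogen gives the lower number of this pair. The change does not remove the effect, however, as compound 3 still gives 250 nM, and no supporting data are available to show what lies behind the rise.

From the compounds shown here alone, with only this one substituted nitrogen to judge from, it remains open whether the rise comes from the fluorine atoms, the methyl ester or simply the added heavy atoms as a whole. Also open, going by these compounds, is how this assay would respond to a plain methyl or an acetyl on this nitrogen, or to a carboxylic acid in place of the methyl ester.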